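The source may report more compounds than this note shows. Statements on the series, on what has been measured and on what is new or still open speak of the compounds shown alone.

In a functional assay on A2780 cells (Homo sapiens) for antiproliferative activity, read by CellTiter-Glo, with a stated time of 4 days (a lower number here means a stronger inhibitor, a higher number a weaker inhibitor), the compounds with an entry so far are these:

- compound 1 `CC(=O)NCc1ncc2cc(COc3ccc(C(=O)NCc4cccnc4)cc3)n(CCC3CCCCC3)c2n1` gives 15 nM in this test
- compound 2 `O=C(NCc1cccnc1)Nc1ccc(CN2C(=O)c3ccccc3C2=O)cc1` gives 100 nM in this test
- compound 3 `O=C(/C=C/c1cccnc1)Nc1ccc(CN2C(=O)c3ccccc3C2=O)cc1` has the entry "not determined" (no result reported) and so offers no number

Of the two numbers, compound 2 holds the higher. Its nearest neighbour is compound 1, and the gap between them lies beyond the scatter of repeat measurements. Compound 3 cannot be placed on this scale.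

Compound 4 `O=C(Nc1ccc(CN2C(=O)c3ccccc3C2=O)cc1)[C@@H]1C[C@H]1c1cccnc1` has not yet been measured. It differs from compound 2 in one place, with 2-(pyridin-3-yl)cyclopropyl in place of ((pyridin-3-yl)methyl)amino on a carbonyl carbon is the counted change.

Within the data shown here, no measured pair shows what this exchange does, and compound 1 differs from compound 2 too widely to serve as a direct guide. Compound 1 at 15 nM shows only that this assay can read well under the number of compound 2. A moderate step towards a lower number is therefore expected, probably beyond the scatter, though the uncertainty is wide and a step of no real size cannot be excluded.

The estimated change is a 3.3-fold lower number from compound 2 to compound 4 (0.52 log units; beyond the scatter) in this reading. For compound 4 the expected value is 30 nM with 6 nM to 150 nM as the estimated range.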

Compound 4, half-maximal inhibitory concentration: > 2500 nM
Compound 4: a limit, no number; the forecaster's own chance of this, stated with the estimate: 5%; at least 83-fold (1.92 log units) between middle value and limit.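

In this assay compound 4 gives > 2500 nM, which is a limit of the assay and not a number. Among these compounds, this is the first reading of a change at this place, on a carbonyl carbon whose other neighbours are an amide-type nitrogen, and exchanging ((pyridin-3-yl)methyl)amino for 2-(pyridin-3-yl)cyclopropyl gives an at least 25-fold higher number from compound 2 to compound 4 (1.39 log units; beyond the scatter), a large step that shows this place does not tolerate every group carrying the pyridine ring. The step therefore marks a minimum rather than an exact size, and it rests on a limit rather than on two numbers: the limit of > 2500 nM in this assay, at which 1 of the 4 values shown sits.

The steps involving compound 3 cannot be read, as it offers no number, and the compounds shown do not separate the hydrogen-bond donor that leaves from the three-membered ring and the two defined stereocentres that enter. Also open, as far as these compounds go, is how this assay would read a plain ethyl chain carrying the pyridin-3-yl group, or the opposite stereoisomer of the 2-(pyridin-3-yl)cyclopropyl group, on the same carbonyl carbon.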